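Replacing 3-Bromophenyl with 2-Methoxyphenyl on Compound 1

The source may report more compounds than this note shows. Statements on the series, on what has been measured and on what is new or still open speak of the compounds shown alone.

compound 1: `COc1cc2ncnc(Nc3cccc(Br)c3)c2cc1OCCCCC(=O)Nc1ccc(S(N)(=O)=O)cc1` — 9750 nM
compound 2: `COc1cc2ncnc(Nc3cccc(Cl)c3F)c2cc1OCCCCC(=O)Nc1ccc(S(N)(=O)=O)cc1` — 5560 nM
compound 3: `COc1ccccc1Nc1ncnc2cc(OC)c(OCCCCC(=O)Nc3ccc(S(N)(=O)=O)cc3)cc12` — not yet measured

Among the measured compounds shown here, in a functional assay on A-431 cells (Homo sapiens) for antiproliferative activity, read by MTT assay, with a stated time of 72 h (on this read-out lower numbers stand for stronger inhibition and higher numbers for weaker inhibition), compound 1 gives 9750 nM, the highest of the two numbers measured so far. For the measured compounds named here, compound 2 gives 5560 nM in this assay, and the only measured step, a 1.8-fold lower number from compound 1 to compound 2 (0.24 log units; within the scatter), lies within the scatter. Compound 3 differs from compound 1 in the same place: 2-methoxyphenyl in place of 3-bromophenyl on a nitrogen on an aromatic ring. The step from compound 1 to compound 2 bears on this change, since it also alters the ring on the nitrogen on an aromatic ring, but it was small and gives no firm direction. Going by the values given here, with only that step to lean on, the expected change is modest, a 1.8-fold higher number from compound 1 to compound 3 (0.27 log units; within the scatter), leaning toward a higher number but with wide uncertainty. Compound 3 is therefore estimated at 18000 nM in this assay, with a range from 5000 nM to 60000 nM.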

Compound 3, half-maximal inhibitory concentration: 24200 nM
The estimate for compound 3 lay 1.3-fold (0.13 log units) below the measured number, within the range that was stated.
By their numbers in this assay, from the lowest: compounds 2 and 1 (each within the scatter of the next); then compound 3.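

In this assay, the group on this nitrogen on an aromatic ring now proves able to shift the number beyond the scatter, which the earlier change between 3-bromophenyl and 3-chloro-2-fluorophenyl did not show: 2-methoxyphenyl in place of 3-bromophenyl gives a 2.5-fold higher number from compound 1 to compound 3 (0.39 log units; beyond the scatter). Set against 3-chloro-2-fluorophenyl, the same 2-methoxyphenyl group gives a larger step, a 4.4-fold higher number from compound 2 to compound 3 (0.64 log units; beyond the scatter), so both halogen-bearing rings give lower numbers than the 2-methoxyphenyl ring. Nothing at hand says why the number rises with this change.

The compounds shown leave open how a plain phenyl, or a phenyl bearing an amine or a carboxylic acid, would stand on this nitrogen. They also leave open whether the same order would hold with a longer chain on the shared core.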